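Fluoro removal on the central ring of compound 2

A few compounds are considered here, and "the series" means these few. Any claim that something is new, unique, unknown or untested is made for them only; others in the source may bear on it.

Measured compounds:
compound 1 `COc1ccc2nc(Nc3nc(Nc4ccc(S(N)(=O)=O)cc4)ncc3F)sc2c1` — 13000 nM
compound 2 `COc1ccc2nc(Nc3nc(Nc4ccc(S(C)(=O)=O)cc4)ncc3F)sc2c1` — 25400 nM

Both compounds share the same core and differ only at the sulfonyl sulfur. In a functional assay on HeLa cells (Homo sapiens) for antiproliferative activity, read by MTT assay, with a stated time of 48 h (on this read-out lower numbers stand for stronger inhibition and higher numbers for weaker inhibition), compound 1 gives 13000 nM and compound 2 gives 25400 nM; the step of a 2.0-fold higher number from compound 1 to compound 2 (0.29 log units; within the scatter) lies within the scatter, so the two numbers are not distinguished. Compound 2 holds the higher of the two numbers shown, with compound 1 as its only neighbour.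

Compound 3 `COc1ccc2nc(Nc3ccnc(Nc4ccc(S(C)(=O)=O)cc4)n3)sc2c1` is the next step. It differs from compound 2 by hydrogen in place of fluoro on an aromatic carbon, on an aromatic carbon of a six-membered aromatic ring with 2 nitrogen, two atoms from the ring nitrogen. For the measured compounds named here, no measured step touches this position: the only step available, from compound 1 to compound 2, concerns the sulfonyl group and was within the scatter. The effect of removing the fluoro is therefore unsupported by data in this assay, and the expectation must stay broad.

Compound 3 is expected to give about 35000 nM in this assay, within 12000 nM to 100000 nM, a step of a 1.4-fold higher number from compound 2 to compound 3 (0.14 log units; within the scatter) that is estimated rather than anchored.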

Compound 3, half-maximal inhibitory concentration: 4130 nM
Beside the measured number, compound 3's estimate is 8.5-fold (0.93 log units) above it, outside the stated range (below it).
By their numbers in this assay, from the lowest: compound 3; then compounds 1 and 2 (each within the scatter of the next).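

In this assay, the aromatic carbon two atoms from the ring nitrogen proves to be a place where a single change moves the number: hydrogen in place of fluoro gives a 6.2-fold lower number from compound 2 to compound 3 (0.79 log units; beyond the scatter). For the compounds shown here, the only earlier comparison, methyl in place of amino on the sulfonyl sulfur, gave a 2.0-fold higher number from compound 1 to compound 2 (0.29 log units; within the scatter), so this is the first step that can be read as a real difference, and it shows that the fluoro is not needed for activity in this pair, whose number is lower without it. Nothing available explains why the number falls when the fluoro leaves.

Going by these compounds, the finding rests on one pair with the methyl group on the sulfonyl sulfur, so it remains open whether the same change gives a step of similar size with the amino group on that sulfur, as in compound 1. Also open, on these data alone, is how this position responds to groups other than fluoro and hydrogen, such as chloro, methyl or nitrile, and whether any of them takes the number lower still.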